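This account rests on a few compounds, and the source may have more. Where it says the series, first, only, none or still open, it means among the compounds named here.

In an ADME assay on HepG2 cells (Homo sapiens) for cytotoxicity, read by luminescence, with a stated time of 72 h (on this read-out lower numbers stand for an effect already at smaller amounts and higher numbers for an effect only at larger amounts of compound), three compounds have been measured so far. Compound 1 `CCOC(=O)c1c(-c2cccc(OC)c2)[nH]c2cc(Cl)c(Cl)cc2c1=O` gives only a limit of the assay, > 21500 nM. Compound 2 `CCOC(=O)c1c(-c2cccc(Oc3ccccc3)c2)[nH]c2cc(Cl)c(Cl)cc2c1=O` also gives only a limit in this assay, > 21500 nM. The change between them is phenyl in place of methyl on an oxygen on an aromatic ring, and the step it made is a step that the two limits leave unreadable from compound 1 to compound 2, since both values sit at the limit of > 21500 nM in this assay, at which 3 of the 3 values shown sit. Compound 3 `CCOC(=O)c1c(-c2cccc(OC)c2)[nH]c2cc(OC)c(F)cc2c1=O` likewise gives only a limit in this assay, > 21500 nM. How the core of compound 1 and the core of compound 3 differ is not broken down here. Compound 4 `CCOC(=O)c1c(-c2cccc(Oc3ccccc3)c2)[nH]c2cc(OC)c(F)cc2c1=O` has not been measured; it differs from compound 3 by phenyl in place of methyl on an oxygen on an aromatic ring, the same change as from compound 1 to compound 2. The step expected in this assay is a step that the limit leaves unreadable from compound 3 to compound 4, resting on a step that the two limits leave unreadable from compound 1 to compound 2. Compound 4 is expected to give 30000 nM, between 12000 nM and 90000 nM, most likely again only a limit.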

Compound 4, half-maximal effective concentration: > 21500 nM
Compound 4: no number, only a limit (the forecaster's own chance of this, stated with the estimate: 85%); the middle value lies beyond the limit too.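

No step can be read from compound 3 to compound 4, because both sit at the same limit: the limit of > 21500 nM in this assay, at which 4 of the 4 values shown sit.

Whether methoxy to phenoxy or the difference between the cores has any effect stays open: no compound shown gives a number in this assay.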